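Switching the double bond geometry in a nitro-bearing enone

This account rests on a few compounds, and the source may have more. Where it says the series, first, only, none or still open, it means among the compounds named here.

Measured compounds:
compound 1, `CC(=O)OC/C(=C\c1ccc(Cl)cc1)C(=O)c1ccccc1`, 4800 nM
compound 2, `CC(=O)OC/C(=C\c1ccc([N+](=O)[O-])cc1)C(=O)c1ccccc1`, 23000 nM

In a functional assay on WiDr cells (Homo sapiens) for inhibition, read by sulforhodamine B assay, with a stated time of 48 h (a lower number here means a stronger inhibitor of growth, a higher number a weaker inhibitor of growth), compound 1, `CC(=O)OC/C(=C\c1ccc(Cl)cc1)C(=O)c1ccccc1`, gives 4800 nM. In this assay compound 2, `CC(=O)OC/C(=C\c1ccc([N+](=O)[O-])cc1)C(=O)c1ccccc1`, gives 23000 nM. Among the two numbers, compound 2 stands highest, and its nearest neighbour is compound 1 at a distance given by a 4.8-fold higher number from compound 1 to compound 2 (0.68 log units; beyond the scatter), a change that involves a nitro in place of chloro on an aromatic carbon.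

Compound 3, `CC(=O)OC/C(=C/c1ccc([N+](=O)[O-])cc1)C(=O)c1ccccc1`, is the next compound to be considered. Its relation to compound 2 is this: the two compounds have the same atoms and bonds and differ only in configuration as drawn: 1 of 1 stereo elements differ; a double bond is drawn E in compound 2 and Z in compound 3. Among the measured compounds shown here, no measured step concerns a change of this kind; the single step available, a 4.8-fold higher number from compound 1 to compound 2 (0.68 log units; beyond the scatter), alters a substituent on the aromatic ring and says nothing about the drawn geometry of the double bond. The data therefore give no direction for this assay, and a step of no more than the usual scatter is the neutral expectation, with wide uncertainty either way.

On that basis compound 3 is estimated at 23000 nM, with a range from 7000 nM to 75000 nM. This estimate corresponds to an expected step of no change at the digits printed from compound 2 to compound 3 (within the scatter).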

Compound 3, concentration for 50% growth inhibition: 83000 nM
Estimate against measurement, compound 3: 3.6-fold (0.56 log units) below; the measured number lies above the stated range.
By their numbers in this assay, from the lowest: compound 1; then compound 2; then compound 3.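

In this assay, among the compounds shown here, the drawn geometry of the double bond proves to matter in its own right: the move gives a 3.6-fold higher number from compound 2 to compound 3 (0.56 log units; beyond the scatter), whereas the only earlier step, a 4.8-fold higher number from compound 1 to compound 2 (0.68 log units; beyond the scatter), concerned the substituent on the aromatic ring. Within this nitro pair, the compound drawn E is therefore the stronger inhibitor of growth and the compound drawn Z the weaker, so the position of the aryl group across the double bond joins the ring substituent as something that moves the number. The step can be assigned to geometry alone, with no group entering or leaving, because of this: the fact that compounds 2 and 3 differ only in the configuration as drawn.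

The compounds shown do not tell whether the same direction or size of step holds for the chloro compound 1, which has no partner drawn Z among them, or for a ring carrying an amine or a methoxy group. They also leave open how either geometry would behave if the acetate ester gave way to a carboxylic acid or a longer chain, and why the geometry changes the number at all.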